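Changing the Amide Substituent in a Cell Toxicity Series

A few compounds are considered here, and "the series" means these few. Any claim that something is new, unique, unknown or untested is made for them only; others in the source may bear on it.

Of the compounds shown here, three have so far been tested in a toxicity assay on HepG2 cells (Homo sapiens) for inhibition, read by CellTiter-Glo, with a stated time of 48 h; a lower number here means a stronger inhibitor, a higher number a weaker inhibitor. Compound 1 `Cc1cc(C)cc(NC(=O)COc2cc(C)nc3ccccc23)c1` reaches only the boundary of the measurement, > 100000 nM, which is a limit and not a number. Compound 2 `COc1ccc2nc(C)cc(OC3CCN(c4ccccc4)C3=O)c2c1` gives 100000 nM in this assay. Compound 3 `COc1ccc2nc(C)cc(OCC(=O)Nc3cc(F)cc(F)c3)c2c1` also stops at the boundary, > 100000 nM, again a limit rather than a number. Compound 3 thus stands at the limit of > 100000 nM in this assay, at which 2 of the 3 values shown sit, so its value can only be set side by side with that of compound 2 without any order between them.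

Compound 4 `COc1ccc2nc(C)cc(OCC(=O)Nc3noc(C)c3C)c2c1` has not yet been measured in this assay. It differs from compound 3 in one place: 4,5-dimethyl-1,2-oxazol-3-yl in place of 3,5-difluorophenyl on an amide-type nitrogen. For the measured compounds named here, no step between measured compounds is available to calibrate this change. Because compound 3 sits at the limit of > 100000 nM in this assay, at which 2 of the 3 values shown sit, the step from compound 3 to compound 4 is expected to be none beyond the scatter, namely a number no higher from compound 3 to compound 4 (the limit leaves the size open). Compound 4 is accordingly expected to give 100000 nM, within a range from 50000 nM to 200000 nM.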

Compound 4, half-maximal inhibitory concentration: > 100000 nM
Compound 4 was reported as a limit; the forecaster's own chance of this, stated with the estimate: 80%; the middle value sits exactly at the limit.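

No step can be read from compound 3 to compound 4, because both values are limits and not numbers: the limit of > 100000 nM in this assay, at which 3 of the 4 values shown sit.

The compounds shown leave open how 4,5-dimethyl-1,2-oxazol-3-yl and 3,5-difluorophenyl on an amide-type nitrogen compare in this assay.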